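The compounds below may be only part of what the source reports. "The series", "measured", "known", "first", "only" and "open" are said of these compounds alone.

Measured so far in an in vitro assay on IMR-32 cells for displacement of a labelled ligand from corticotropin-releasing factor receptor 1 (Homo sapiens); on this read-out higher numbers stand for weaker inhibition and lower numbers for stronger inhibition:
compound 1 `CCCN(CC1CC1)C(=O)c1c(C)nc2n1CCC(=O)N2c1c(C)cc(C)cc1C` — > 5000 nM, a limit of this assay
compound 2 `CCCN(CC1CC1)C(=O)c1c(CC)nc2n1CCC(=O)N2c1c(C)cc(C)cc1C` — > 5000 nM, a limit of this assay

Compound 2 sits only at a limit in this assay. The step from compound 1 to compound 2, a step that the two limits leave unreadable from compound 1 to compound 2, cannot be read because both values sit at the limit of > 5000 nM in this assay, at which 2 of the 2 values shown sit. Compound 3 `CCc1nc2n(c1C(=O)N(CC)Cc1ccccc1)CCC(=O)N2c1c(C)cc(C)cc1C` differs from compound 2 by benzyl(ethyl)amino in place of (cyclopropylmethyl)(propyl)amino on a carbonyl carbon. Going by the values given here, no measured step bears on this change, so no direction beyond the scatter is expected; compound 3 is estimated to remain near the limit, with the estimated step from compound 2 to compound 3 being a number no higher from compound 2 to compound 3 (the limit leaves the size open). Compound 3 is therefore expected at 5000 nM, range 800 nM to 30000 nM.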

Compound 3, inhibition constant: > 5000 nM
Compound 3 was reported as a limit; the forecaster's own chance of this, stated with the estimate: 70%; the middle value lies on the limit itself.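

The step from compound 2 to compound 3 cannot be read, because both compounds sit at a limit: the limit of > 5000 nM in this assay, at which 3 of the 3 values shown sit.

The compounds shown leave open whether either change, on the saturated chain or on the carbonyl carbon, shifts inhibition at all.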